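The source may report more compounds than this note shows. Statements on the series, on what has been measured and on what is new or still open speak of the compounds shown alone.

Measured so far:
- compound 1, `CN1[C@@H]2c3[nH]c4ccccc4c3C[C@H]1[C@H](C#N)N1[C@@H](CN3C(=O)c4ccccc4C3=O)c3[nH]c4ccccc4c3C[C@@H]21`: 40 nM in a functional assay on HCT-116 cells (Homo sapiens) for cytotoxicity, read by MTT assay, with a stated time of 72 h; on this read-out lower numbers stand for stronger inhibition and higher numbers for weaker inhibition
- compound 2, `CN1[C@@H]2c3[nH]c4ccccc4c3C[C@H]1[C@H](C#N)N1[C@@H](CNC(=O)c3ccc(Cl)cc3)c3[nH]c4ccccc4c3C[C@@H]21`: 630 nM in this assay
- compound 3, `COc1ccc(C(=O)NC[C@H]2c3[nH]c4ccccc4c3C[C@H]3[C@H]4c5[nH]c6ccccc6c5C[C@@H]([C@H](C#N)N23)N4C)cc1`: 430 nM in this assay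

Compound 3 sits second highest of the three numbers. Its nearest neighbour is compound 2, with a 1.5-fold lower number from compound 2 to compound 3 (0.17 log units; within the scatter) separating them; the step back to compound 1 is far larger, an 11-fold higher number from compound 1 to compound 3 (1.03 log units; beyond the scatter), and the step from compound 1 to compound 2 is of the same order, a 16-fold higher number from compound 1 to compound 2 (1.20 log units; beyond the scatter). Those two large steps concern the exchange of the whole group on the chain carbon and do not bear on the change considered here.

Compound 4, `CCc1ccc(C(=O)NC[C@H]2c3[nH]c4ccccc4c3C[C@H]3[C@H]4c5[nH]c6ccccc6c5C[C@@H]([C@H](C#N)N23)N4C)cc1`, differs from compound 3 only in the change (ethyl in place of methoxy on an aromatic carbon). Among the measured compounds shown here, the one measured step that touches this position is the exchange from compound 2 to compound 3, which stayed within the scatter. With the same anchor kept and only the substituent on the aromatic ring exchanged, no step beyond the scatter is expected in this assay in either direction; the expected step is a 1.0-fold higher number from compound 3 to compound 4 (0.02 log units; within the scatter). Compound 4 is therefore estimated at 450 nM, with a range from 200 nM to 1000 nM.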

Compound 4, half-maximal inhibitory concentration: 100 nM
Compound 4: the middle estimate sits 4.5-fold (0.65 log units) above what was measured; the measured number lies below the stated range.
By their numbers in this assay, from the lowest: compound 1; then compound 4; then compounds 3 and 2 (each within the scatter of the next).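

In this assay the substituent on the aromatic carbon para to a large group does matter: ethyl in place of methoxy gives a 4.3-fold lower number from compound 3 to compound 4 (0.63 log units; beyond the scatter) and ethyl in place of chloro gives a 6.3-fold lower number from compound 2 to compound 4 (0.80 log units; beyond the scatter), both beyond the scatter, whereas the earlier exchange of chloro for methoxy stayed within it. Among the three substituents shown, ethyl alone stands apart, while methoxy and chloro cannot be told apart, so the position is sensitive to some exchanges and not to others. The amide series still does not match the group with the five-membered non-aromatic ring, as a 2.5-fold higher number from compound 1 to compound 4 (0.40 log units; beyond the scatter) remains beyond the scatter, although compound 4 lies closer to compound 1 than compound 2 or compound 3 do. No measurement in hand accounts for the separation of ethyl from methoxy and chloro.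

On these data alone, whether the lower number belongs to ethyl in particular or extends to methyl, propyl or a longer chain at this place remains open. Also open, as far as these compounds go, is how an amine or a carboxylic acid on the same aromatic carbon would read in this assay, and whether any substituent here could bring the amide series level with compound 1.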